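The source may report more compounds than this note shows. Statements on the series, on what has been measured and on what is new or still open speak of the compounds shown alone.

Of the compounds shown here, two sharing one core have been tested in an assay on isolated protein for inhibition of DNA topoisomerase 1 (Homo sapiens), with a stated time of 30 min, tested at 100 uM; a lower number here means a weaker effect, a higher number a stronger effect of the compound at the concentration tested. Compound 1 `Cc1ccc2nc(-c3cccc(F)c3)[nH]c(=O)c2c1` gives 82.9%, the lower of the two numbers. Compound 2 `Cc1ccc2c(=O)[nH]c(-c3ccccc3OC(F)(F)F)nc2c1` gives 100%, a gap beyond the usual scatter. Compound 3 `COc1cccc(-c2nc3ccc(C)cc3c(=O)[nH]2)c1` is not yet measured; it differs from compound 1 in one place: methoxy in place of fluoro on an aromatic carbon. Among the compounds with values here, no measured pair shows this exchange of methoxy for fluoro, so only a small shift is expected, likely within the scatter in either direction, a number 2.9 percentage points lower from compound 1 to compound 3 (within the scatter). Compound 3 is estimated at 80% in this assay, between 55% and 100%.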

Compound 3, a percentage reported as inhibition, at one concentration (the size of the read-out at that concentration, not a potency): 71.8%
The estimate for compound 3 lay 8.2 percentage points above the measured number; measured number inside the range.
By their numbers in this assay, from the lowest: compound 3; then compound 1; then compound 2.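

Exchanging fluoro for methoxy on this aromatic carbon, meta to a large group, gives a number 11.1 percentage points lower from compound 1 to compound 3 (beyond the scatter) in this assay, the first single-place change seen in this series. The position is therefore not indifferent to its group: even this small exchange, which brings in one hydrogen-bond acceptor, moves the read-out by a modest amount. Nothing measured here bears on why the number falls.

From the compounds shown here alone, whether the oxygen, the added carbon or the loss of fluorine matters most remains open. A hydroxyl group or an amine at this position could help tell these apart.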